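Swapping Chloro for Amino on the Fused Ring

The compounds below may be only part of what the source reports. "The series", "measured", "known", "first", "only" and "open" are said of these compounds alone.

Compound 1 `Nc1nn(C(=O)Nc2ccc(Cc3ccccc3)cc2)c2ccccc12`: 13000 nM
Compound 2 `Nc1nn(C(=O)Nc2ccc(Cc3ccccc3)cc2)c2ccc(Cl)cc12`: 14700 nM

In a functional assay on NCI-H460 cells (Homo sapiens) for antiproliferative activity, read by sulforhodamine B assay, with a stated time of 48 h (on this read-out lower numbers stand for stronger inhibition of growth and higher numbers for weaker inhibition of growth), compound 2 gives 14700 nM, the higher of the two numbers, with compound 1 sitting close by. For the measured compounds named here, the one measured step, a 1.1-fold higher number from compound 1 to compound 2 (0.05 log units; within the scatter), shows that exchanging the substituent at this ring position barely moved the read-out. Compound 3 `Nc1ccc2c(c1)c(N)nn2C(=O)Nc1ccc(Cc2ccccc2)cc1` carries amino in place of chloro on an aromatic carbon. Going by the values given here, no measured step covers an amino group here, so the only guide is that this position tolerated chloro without change. The expected step of a 1.1-fold lower number from compound 2 to compound 3 (0.02 log units; within the scatter) is therefore none beyond the scatter. Compound 3 is estimated at 14000 nM, within 5000 nM to 40000 nM.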

Compound 3, concentration for total growth inhibition: 23800 nM
For compound 3 the middle estimate is 1.7-fold (0.23 log units) below the measured one; measured number inside the range.
By their numbers in this assay, from the lowest: compounds 1, 2 and 3 (each within the scatter of the next).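

Amino on this ring carbon stays within the usual scatter in this assay, both against chloro (a 1.6-fold higher number from compound 2 to compound 3 (0.21 log units; within the scatter)) and against hydrogen (a 1.8-fold higher number from compound 1 to compound 3 (0.26 log units; within the scatter)). This position has now carried hydrogen, chloro and amino, including a group that adds a hydrogen-bond donor, with no step beyond the scatter. Nothing available explains this lack of separation. The compounds shown leave open whether a carboxylic acid, a methoxy group or a longer chain on this ring carbon would move the number beyond the scatter.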